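Fluoro for methoxy on the aryl of compound 2

The source may hold more compounds than are shown below. What is called first, only, known or untested is meant among the compounds shown, and "the series" means these compounds.

Compound 2 `COc1ccc(-n2c(SCC(=O)Nc3nc4ccc(C(F)(F)F)cc4s3)nc3c(c2=O)SCC3)cc1` gives the highest of the three numbers in an assay on L cells for inhibition of Protein-serine O-palmitoleoyltransferase porcupine (Mus musculus), read by reporter gene assay, with a stated time of 24 h (on this read-out higher numbers stand for an effect only at larger amounts of compound and lower numbers for an effect already at smaller amounts), at 100 nM. Compound 3 `COc1ccc(-n2nc(C(=O)NCC(=O)Nc3nc4ccc(OC)cc4s3)c3ccccc3c2=O)cc1` gives 60 nM, which lies within the scatter of compound 2, so no order between the two can be read. Compound 1 `COc1ccc(-n2c(SCC(=O)Nc3nc4ccc(Cl)cc4s3)nc3c(c2=O)SCC3)cc1` gives 35 nM, and the step of a 2.9-fold higher number from compound 1 to compound 2 (0.46 log units; beyond the scatter) is beyond the scatter; that step is trifluoromethyl in place of chloro on an aromatic carbon.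

Compound 4 `O=C(CSc1nc2c(c(=O)n1-c1ccc(F)cc1)SCC2)Nc1nc2ccc(C(F)(F)F)cc2s1` is not yet measured. It differs from compound 2 by fluoro in place of methoxy on an aromatic carbon. Among the measured compounds shown here, no measured step bears on this change: the only step in hand, a 2.9-fold higher number from compound 1 to compound 2 (0.46 log units; beyond the scatter), concerns a different group, and compound 3 differs from compound 2 in more than one place, so its value alone cannot be attributed to the aryl substituent. With nothing to point either way, the expectation is a change no larger than the scatter, and the estimated step is no change at the digits printed from compound 2 to compound 4 (within the scatter). Compound 4 is therefore expected to give about 100 nM, with a range from 35 nM to 300 nM.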

Compound 4, half-maximal effective concentration: 100 nM
The estimate for compound 4 equals the measured number at the digits printed, and the stated range covers the measured number.
By their numbers in this assay, from the lowest: compounds 1, 3, 2 and 4 (each within the scatter of the next, the first and the last beyond it).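

In this assay, the change from 4-methoxyphenyl to 4-fluorophenyl gives no change at the digits printed from compound 2 to compound 4 (within the scatter), so this aromatic carbon, para to a large group, carries either substituent with no shift in the number. Among the compounds shown here, this is the first single-place reading on the aryl substituent, as the earlier step, a 2.9-fold higher number from compound 1 to compound 2 (0.46 log units; beyond the scatter), concerns the trifluoromethyl and chloro groups elsewhere on the molecule. No supporting measurement bears on why methoxy and fluoro read alike here.

Going by these compounds, whether an amine, a carboxylic acid or a longer alkoxy chain on this carbon would also leave the number in place remains open. Also open, on these data alone, is whether fluoro in place of methoxy reads the same when chloro, as in compound 1, replaces trifluoromethyl.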